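This account rests on a few compounds, and the source may have more. Where it says the series, first, only, none or still open, it means among the compounds named here.

In a functional assay on L5178Y cells (Mus musculus) for antiproliferative activity, read by MTT assay (on this read-out higher numbers stand for weaker inhibition and lower numbers for stronger inhibition), compound 1 (`CC(=O)c1ccc(OCCCN2CCN(c3ncccn3)CC2)cc1`) gives 53.2 nM and compound 2 (`CCC(=O)c1ccc(OCCCN2CCN(c3ncccn3)CC2)cc1`) gives 36.9 nM so these two values stand within the scatter of each other. Compound 3 (`CC(=O)c1ccc(OCCCN2CCN(c3ccncc3)CC2)cc1`) carries pyridin-4-yl in place of pyrimidin-2-yl on an amine nitrogen in a ring and otherwise matches compound 1. Within the data shown here, the only measured step (a 1.4-fold lower number from compound 1 to compound 2 (0.16 log units; within the scatter)) lies on a saturated chain carbon bound to a carbonyl carbon, a different place, and it bears on this change only indirectly. No group other than pyrimidin-2-yl has been measured on the amine nitrogen, so the data give no direction. No step beyond the scatter is expected in this assay for now. For compound 3 the estimated value is 50 nM with an expected range from 15 nM to 170 nM for repeated measurements. The expected step (a 1.1-fold lower number from compound 1 to compound 3 (0.03 log units; within the scatter)) is correspondingly small, and the wide range reflects how little the series shows so far.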

Compound 3, half-maximal inhibitory concentration: 42.3 nM
The estimate for compound 3 lay 1.2-fold (0.07 log units) above the measured number, and the stated range covers the measured number.
By their numbers in this assay, from the lowest: compounds 2, 3 and 1 (each within the scatter of the next).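

In this assay, the amine nitrogen in the ring now carries a second group, and the swap gives a 1.3-fold lower number from compound 1 to compound 3 (0.10 log units; within the scatter). Pyridin-4-yl, with 1 hetero atom and 1 hydrogen-bond acceptor, thus stands in for pyrimidin-2-yl, with 2 hetero atoms and 2 hydrogen-bond acceptors, with no step beyond the scatter, though this single pair is all that speaks to the position. Nothing measured on hand offers an explanation for this result.

From the compounds shown here alone, whether this position responds at all remains open: phenyl, with no hetero atom in the ring, or a small alkyl group such as methyl on the same nitrogen could test that. Going by these compounds, it is also open whether pyridin-4-yl and the longer ketone chain of compound 2 would behave independently when combined.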